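Swapping the Aryl Group on the Shared Core of Compound 2

This account rests on a few compounds, and the source may have more. Where it says the series, first, only, none or still open, it means among the compounds named here.

Among the compounds with values here, in a functional assay for inhibition, tested at 60 ug/mL (a higher number here means a stronger effect of the compound at the concentration tested, a lower number a weaker effect), compound 2 `COc1cc(-c2cc(-c3cc(C(C)C)c(O)cc3C)[nH]c(=O)c2C#N)ccc1O` gives 37.5%, the lowest of the three numbers measured so far; compound 3 `Cc1cc(O)c(C(C)C)cc1-c1cc(-c2ccc(N(C)C)cc2)c(C#N)c(=O)[nH]1` gives 53% and compound 1 `COc1cc(-c2cc(-c3cc(C(C)C)c(O)cc3C)[nH]c(=O)c2C#N)cc(OC)c1OC` gives 71%. The unmeasured compound 4 `Cc1cc(O)c(C(C)C)cc1-c1cc(-c2ccccc2Cl)c(C#N)c(=O)[nH]1` differs from compound 2 by one change: 2-chlorophenyl in place of 4-hydroxy-3-methoxyphenyl on an aromatic carbon. Within the data shown here, only one measured step bears on this change, a number 15.5 percentage points higher from compound 2 to compound 3 (beyond the scatter), where the same 4-hydroxy-3-methoxyphenyl was also exchanged for a different aryl group at this place. Because of a number 15.5 percentage points higher from compound 2 to compound 3 (beyond the scatter), a modest rise rather than none beyond the scatter is expected here. The expected step is therefore a number 12.5 percentage points higher from compound 2 to compound 4 (beyond the scatter). Compound 4 is estimated to give 50% in this assay, with a range from 30% to 70%.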

Compound 4, a percentage reported as inhibition, at one concentration (the size of the read-out at that concentration, not a potency): 26%
Estimate against measurement, compound 4: 24 percentage points above, and the stated range ends above it.
By their numbers in this assay, from the lowest: compound 4; then compound 2; then compound 3; then compound 1.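

In this assay this position can also go the other way: 2-chlorophenyl in place of 4-hydroxy-3-methoxyphenyl brings a number 11.5 percentage points lower from compound 2 to compound 4 (beyond the scatter), so the rise seen with 4-(dimethylamino)phenyl does not hold for every aryl group entering here. Against 4-(dimethylamino)phenyl, the same group brings a number 27 percentage points lower from compound 3 to compound 4 (beyond the scatter), which shows that the read-out depends on which aryl group sits at this place. Nothing measured here accounts for these drops. The compounds shown leave open whether the chlorine matters, which plain phenyl would test, and how an amine or a carboxylic acid on this aryl ring would read.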